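Compound 4: chloro in place of hydrogen on the shared core

This account rests on a few compounds, and the source may have more. Where it says the series, first, only, none or still open, it means among the compounds named here.

Three compounds have been measured in a functional assay on SAOS-2 cells (Homo sapiens) for inhibition, read by CCK-8 assay, with a stated time of 72 h, tested at 20 uM; a lower number here means less inhibition of growth, a higher number more inhibition of growth at the concentration tested:
compound 1 `CC(C)(C)OC(=O)/C=C1/C(=O)Nc2ccccc21` gives 83.3%
compound 2 `CC(C)c1ccc2c(c1)/C(=C\C(=O)OC(C)(C)C)C(=O)N2` gives 82.8%
compound 3 `COc1ccc2c(c1)/C(=C\C(=O)OC(C)(C)C)C(=O)N2` gives 82%

Compound 1 stands in a tight cluster with the other two: a number 0.5 percentage points lower from compound 1 to compound 2 (within the scatter) and a number 1.3 percentage points lower from compound 1 to compound 3 (within the scatter), so none of the three can be set apart from the others. Compound 4 `CC(C)(C)OC(=O)/C=C1/C(=O)Nc2c(Cl)cccc21` differs from compound 1 by chloro in place of hydrogen on an aromatic carbon. The two measured steps that bear on this are also replacements of a hydrogen on an aromatic carbon of the shared core, by isopropyl and by methoxy, and both stayed within the scatter. No step beyond the scatter is therefore expected in this assay for the chloro replacement either. Compound 4 is estimated at 82%, within 70% to 90%, meaning an expected step of a number 1.3 percentage points lower from compound 1 to compound 4 (within the scatter).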

Compound 4, percent growth inhibition at one concentration: 82.4%
Estimate against measurement, compound 4: 0.4 percentage points below; the range from low to high includes it.
By their numbers in this assay, from the lowest: compounds 3, 4, 2 and 1 (each within the scatter of the next).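

In this assay the chloro replacement gives a number 0.9 percentage points lower from compound 1 to compound 4 (within the scatter). This adds a halogen to the replacements of hydrogen that cannot be told apart from compound 1, and it does so at a place ortho to a fused ring and meta to a fused ring. A single chlorine there therefore gives no readable step at the concentration tested. From the compounds shown here alone, whether an amine or a carboxylic acid at this place would also stay within the scatter remains open. Nothing at hand accounts for the absence of a step.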